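The source may hold more compounds than are shown below. What is called first, only, known or untested is meant among the compounds shown, and "the series" means these compounds.

Measured compounds:
- compound 1, `COc1cc2c(cc1OC)C(CC(=O)Nc1cccc(Cl)c1)CC2`, in a functional assay on the whole organism (strain Swiss Albino) for inhibition, with Mus musculus as the target, in the writhing test, with a stated time of 1 h, at a dose of 100 mg/kg by the oral route (a lower number here means less inhibition, a higher number more inhibition at the dose given (going by the name of the read-out)), compound 1 gives 51.5%
- compound 2, `COc1cc2c(cc1OC)C(CC(=O)Nc1ccc(Br)cc1)CC2`, in this assay compound 2 gives 37.5%

Compound 2 stands at the lower of the two numbers; its nearest neighbour is compound 1, and the difference a number 14 percentage points lower from compound 1 to compound 2 (beyond the scatter) lies beyond the scatter. Compound 3, `COc1cc2c(cc1OC)C(CC(=O)Nc1ccccc1C)CC2`, has not yet been tested in this assay. It differs from compound 2 in one place: 2-methylphenyl in place of 4-bromophenyl on an amide-type nitrogen. Within the data shown here, only one step bears on this change, a number 14 percentage points lower from compound 1 to compound 2 (beyond the scatter), and it concerns a different pair of groups on the same amide-type nitrogen, so it is a weak guide. Nothing shows how a 2-methylphenyl group behaves here. In this assay compound 3 is therefore expected to land near the middle of the two measured values, with a number 7.5 percentage points higher from compound 2 to compound 3 (within the scatter) as the expected step, within the scatter. The estimate for compound 3 is 45%, in the range 25% to 65%.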

Compound 3, a percentage reported as inhibition, in the whole organism at one dose (the size of the read-out at that dose, not a potency): 30%
Compound 3: middle estimate off by 15 percentage points, on the high side; measured number inside the range.
By their numbers in this assay, from the lowest: compounds 3 and 2 (each within the scatter of the next); then compound 1.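

In this assay, the step of a number 7.5 percentage points lower from compound 2 to compound 3 (within the scatter) is small enough that the 4-bromophenyl and 2-methylphenyl groups on the amide-type nitrogen cannot be told apart. The step of a number 21.5 percentage points lower from compound 1 to compound 3 (beyond the scatter) sets compound 3 apart from compound 1, so the 3-chlorophenyl group now stands apart from two different replacements at this position rather than one, with the methyl and bromine groups giving no separable result. Nothing available here explains this difference.

Among the three compounds shown, the group name and the place of the substituent change together, so it stays open whether the higher number of compound 1 goes with chlorine or with the 3-position. Also open, from the compounds shown here alone, is what a 4-chlorophenyl group, a 3-methylphenyl group, or a phenyl bearing an amine or a carboxylic acid would give on this nitrogen.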